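From a Hydroxyl to a Longer Protected Side Chain

The compounds below may be only part of what the source reports. "The series", "measured", "known", "first", "only" and "open" are said of these compounds alone.

Compound 1, `O=C(CN(c1ncnc2c1ncn2C1CCCCO1)C1CC1)N[C@@H](CO)C(=O)OCc1ccccc1`, is tested in a functional assay on the whole organism (Tail, strain ICR) with Mus musculus as the target, in the tail flick test, with a stated time of 120 min, at a dose of 25 umol/kg by the oral route (on this read-out higher numbers stand for a stronger effect at the one dose given and lower numbers for a weaker effect), where compound 1 gives 29.2%. Among the three measured compounds, compound 1 stands second highest; compound 2, `O=C(O)C[C@H](NC(=O)CN(c1nc(Cl)nc2[nH]cnc12)C1CC1)C(=O)O`, gives 22%, and compound 3, `O=C(CN(c1nc(Cl)nc2[nH]cnc12)C1CC1)N[C@@H](CO)C(=O)O`, gives 39%. Both of these lie within the usual scatter of compound 1, so no order among the three can be claimed. Compound 4, `CC(C)(C)OC(=O)NCCCC[C@H](NC(=O)CN(c1ncnc2c1ncn2C1CCCCO1)C1CC1)C(=O)OCc1ccccc1`, differs from compound 1 at one place: 3-((tert-butoxycarbonyl)amino)propyl in place of hydroxy on a saturated chain carbon, two bonds along the chain from an amide-type nitrogen and a carbonyl carbon. Within the data shown here, the only measured step, a number 17 percentage points higher from compound 2 to compound 3 (beyond the scatter), concerns the same place on the chain but exchanges other groups on a differently substituted core, so it does not bear directly on this change; no measured pair shows what follows when the hydroxy is replaced by the longer group. The expectation therefore rests on compound 1 alone, and the step from compound 1 to compound 4 is expected to be a number 3.2 percentage points lower from compound 1 to compound 4 (within the scatter), not beyond the scatter. Compound 4 is thus estimated at 26%, within a range from 5% to 50%.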

Compound 4, a percentage reported as activity, at one dose (the size of the read-out at that dose, not a potency): 28.4%
Compound 4: the middle estimate sits 2.4 percentage points below what was measured, and the stated range covers the measured number.
By their numbers in this assay, from the lowest: compounds 2, 4, 1 and 3 (each within the scatter of the next, the first and the last beyond it).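

In this assay, the swap at this saturated chain carbon gives a small step (a number 0.8 percentage points lower from compound 1 to compound 4 (within the scatter)), even though a group of 11 heavy atoms enters where hydroxy, with 1 heavy atom, leaves. The earlier step at this place (a number 17 percentage points higher from compound 2 to compound 3 (beyond the scatter)) compared hydroxy with carboxy on a different core, whereas this pair shows that, on the core of compound 1, the position accepts the long protected chain with the two numbers staying within the scatter. Nothing measured here offers a reason for this result.

Still open, as far as these compounds go, is how a free amine at the end of this chain, or a plain methyl at the same place, would read. From the compounds shown here alone, the read-out also comes from one dose at one time, so whether the two compounds would stay this close at other doses remains unknown.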